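Pyridin-3-yl in place of the aryl group: cytotoxicity outlook

The compounds below may be only part of what the source reports. "The series", "measured", "known", "first", "only" and "open" are said of these compounds alone.

Compound 3 `CCOC(=O)C1=C(C)N/C(=C/c2cc(C)n(-c3ccc([S+](C)[O-])cc3)c2C)C1=O` stands highest of the three measured compounds in an ADME assay on L6 cells (Rattus norvegicus) for cytotoxicity, read by resazurin assay, with a stated time of 72 h (on this read-out higher numbers stand for an effect only at larger amounts of compound and lower numbers for an effect already at smaller amounts), giving 220000 nM. Compound 1 `CCOC(=O)C1=C(C)N/C(=C/c2cc(C)n(-c3ccc(Cl)cc3)c2C)C1=O` gives 100000 nM in this assay, and compound 2 `CCOC(=O)C1=C(C)N/C(=C/c2cc(C)n(-c3ccc(Br)cc3)c2C)C1=O` gives 100000 nM. The steps of a 2.2-fold higher number from compound 1 to compound 3 (0.34 log units; beyond the scatter) and a 2.2-fold higher number from compound 2 to compound 3 (0.34 log units; beyond the scatter) are modest but beyond the scatter, whereas no change at the digits printed from compound 1 to compound 2 (within the scatter) lies within it.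

Compound 4 `CCOC(=O)C1=C(C)N/C(=C/c2cc(C)n(-c3cccnc3)c2C)C1=O` differs from compound 3 by a group of 6 heavy atoms (5 carbon, 1 nitrogen; one six-membered aromatic ring with 1 hetero atom) in place of a group of 9 heavy atoms (7 carbon, 1 oxygen, 1 sulfur; one six-membered aromatic ring of carbon only), on an aromatic nitrogen. Among the compounds with values here, no measured step exchanges this ring as a whole; the two steps into compound 3 only changed what sits on the carbon-only ring, so they bear on the present change loosely and mainly show that the whole series sits in a narrow band. The expected step of a 1.5-fold lower number from compound 3 to compound 4 (0.17 log units; within the scatter) is therefore small. Because compound 1 gives 100000 nM and compound 2 gives 100000 nM, the lean of that expected step is downward, back toward the band of the halogen compounds. Compound 4 is estimated at 150000 nM, with a range from 60000 nM to 400000 nM.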

Compound 4, half-maximal effective concentration: 160000 nM
Estimate against measurement, compound 4: 1.1-fold (0.03 log units) below, within the range that was stated.
By their numbers in this assay, from the lowest: compounds 1, 2, 4 and 3 (each within the scatter of the next, the first and the last beyond it).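

In this assay, within the data shown here, pyridin-3-yl on the aromatic nitrogen exchanges the whole aryl ring for the first time, and the number stays within the scatter of the sulfur-bearing compound (a 1.4-fold lower number from compound 3 to compound 4 (0.14 log units; within the scatter)) and of both halogen compounds (a 1.6-fold higher number from compound 2 to compound 4 (0.20 log units; within the scatter); a 1.6-fold higher number from compound 1 to compound 4 (0.20 log units; within the scatter)). This position therefore accepts a ring with a nitrogen in place of the carbon-only ring with no readable change on this read-out, so the earlier substituent steps are joined by a change to the ring itself. No supporting measurement bears on why the number holds through this exchange.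

As far as these compounds go, whether pyridin-2-yl or pyridin-4-yl would sit in the same band remains open. So does the outcome of an amine or a carboxylic acid on this ring, or of a saturated ring such as piperidin-4-yl on the same nitrogen.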